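Replacing the 2-bromophenoxy group of compound 2

A few compounds are considered here, and "the series" means these few. Any claim that something is new, unique, unknown or untested is made for them only; others in the source may bear on it.

In a functional assay for inhibition, with Homo sapiens as the target (on this read-out higher numbers stand for weaker binding and lower numbers for tighter binding), compound 1 `CSc1ccccc1OC(C)(C)C1OCC(C/C=C\CCC(=O)O)C(c2cccnc2)O1` gives 89.1 nM and compound 2 `CC(C)(Oc1ccccc1Br)C1OCC(C/C=C\CCC(=O)O)C(c2cccnc2)O1` gives 63.1 nM. For the measured compounds named here, these two values lie within the scatter of each other, so compound 2 stands level with the only other compound measured so far.

The next compound, compound 3 `Cc1ccc(SC(C)(C)C2OCC(C/C=C\CCC(=O)O)C(c3cccnc3)O2)c([N+](=O)[O-])c1`, changes the structure of compound 2 as follows: a group of 11 heavy atoms (7 carbon, 1 nitrogen, 2 oxygen, 1 sulfur; one six-membered aromatic ring of carbon only) in place of a group of 8 heavy atoms (6 carbon, 1 oxygen, 1 bromine; one six-membered aromatic ring of carbon only), on a saturated chain carbon bound to two saturated chain carbons and a saturated ring carbon.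

Going by the values given here, only one measured step bears on this change, and only indirectly. Putting bromo in place of methylsulfanyl on an aromatic carbon gave a 1.4-fold lower number from compound 1 to compound 2 (0.15 log units; within the scatter). That swap touched a single substituent, whereas the new change replaces the whole group, and no measurement covers an exchange of that extent. The data therefore offer no basis for predicting a shift in either direction, and no step beyond the scatter is expected in this assay, although the uncertainty is wide.

The expected outcome is a 1.3-fold higher number from compound 2 to compound 3 (0.10 log units; within the scatter). For compound 3 the estimated value is 80 nM, with an expected range from 25 nM to 250 nM.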

Compound 3, dissociation constant: 158 nM
The estimate for compound 3 lay 2.0-fold (0.30 log units) below the measured number; measured number inside the range.
By their numbers in this assay, from the lowest: compounds 2, 1 and 3 (each within the scatter of the next, the first and the last beyond it).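

In this assay the exchange of the whole group on this saturated chain carbon gave a 2.5-fold higher number from compound 2 to compound 3 (0.40 log units; beyond the scatter) and is the first step in the series to pass beyond the scatter, so this place does respond to a change of the entire group, which the single swap of methylsulfanyl for bromo on the aromatic carbon had not shown. The same group measured against the methylsulfanyl-bearing group gave a 1.8-fold higher number from compound 1 to compound 3 (0.25 log units; within the scatter) and stays within the scatter, so the change reads as a real shift only when set against the 2-bromophenoxy group, and compound 1 stands level with both of the others. No measured evidence on the cause of this step is at hand.

The compounds shown do not separate the contributions of the sulfur, the nitro group and the methyl group within the entering group, since all three arrive in a single exchange. Also open, from the compounds shown here alone, is how the number would respond to an amine or a nitrile on the aromatic ring, or to a plain phenoxy group on this same carbon.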